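The source may hold more compounds than are shown below. What is called first, only, known or untested is meant among the compounds shown, and "the series" means these compounds.

Measured so far in a functional assay for activation of Alpha-1B adrenergic receptor (Homo sapiens), read by calcium flux; on this read-out lower numbers stand for an effect already at smaller amounts and higher numbers for an effect only at larger amounts of compound:
compound 1 `c1cncc(-c2ccccc2OCC2=NCCN2)c1` – 79.4 nM
compound 2 `c1ccc(-c2ccncc2)c(OCC2=NCCN2)c1` – < 100000 nM
compound 3 `Cc1cccc(-c2ccccc2OCC2=NCCN2)n1` – < 100000 nM

Compound 1 holds the only number shown in this assay; the other two values are limits. For compound 2 the value is a limit of the assay, not a number. For compound 3 the value is likewise a limit of the assay. For the measured compounds named here, the one step that connects two measured compounds, a step that the limit leaves unreadable from compound 1 to compound 2, cannot be read in size, because the limit of < 100000 nM in this assay, at which 2 of the 3 values shown sit, sets the boundary at which both further values sit.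

Compound 4 `c1ccc(-c2ccncn2)c(OCC2=NCCN2)c1` is not yet measured. It differs from compound 1 by pyrimidin-4-yl in place of pyridin-3-yl on an aromatic carbon. Going by the values given here, no measured step concerns this exact change. The replacement of pyridin-3-yl by pyridin-4-yl in compound 2 and the 6-methylpyridin-2-yl of compound 3 both end at the limit, so the only pattern visible is that the measured departures from the pyridin-3-yl of compound 1 have not yielded a number. On that thin basis compound 4 is expected to give a weaker response than compound 1, as the step of a 25-fold higher number from compound 1 to compound 4 (1.40 log units; beyond the scatter) states. The estimate for compound 4 in this assay is 2000 nM, with a range from 200 nM to 30000 nM, and a real chance that only a limit is reported.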

Compound 4, half-maximal effective concentration: < 100000 nM
Compound 4: no number, only a limit; the forecaster's own chance of this, stated with the estimate: 35%; the middle value lies beyond the limit too.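

Compound 4 gives < 100000 nM in this assay as a limit and not a number. The steps from compound 1 and from compound 2 to compound 4 therefore cannot be read in size: the limit of < 100000 nM in this assay, at which 3 of the 4 values shown sit. The compounds shown leave open in this assay whether any group other than the pyridin-3-yl of compound 1 gives a number.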